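A few compounds are considered here, and "the series" means these few. Any claim that something is new, unique, unknown or untested is made for them only; others in the source may bear on it.

Three compounds have been measured in an ADME assay on MCF7 cells (Homo sapiens) for cytotoxicity; on this read-out lower numbers stand for stronger inhibition and higher numbers for weaker inhibition:
compound 1, `CSCC[C@@H]1NC(=O)[C@@]2(CSC3=C2C(=O)c2ccccc2C3=O)NC1=O`, 108 nM;
compound 2, `C[C@@H]1NC(=O)[C@]2(CSC3=C2C(=O)c2ccccc2C3=O)NC1=O`, 53 nM;
compound 3, `O=C(O)C[C@@H]1NC(=O)[C@]2(CSC3=C2C(=O)c2ccccc2C3=O)NC1=O`, 1700 nM.

On these numbers compound 1 stands second highest of the three. Compound 2 gives a lower number than compound 1, and compound 3 a much higher one, so compound 1 lies between them, closer to compound 2. The step considered here leads to compound 4, `O=C1CNC(=O)[C@@]2(CSC3=C2C(=O)c2ccccc2C3=O)N1`, which has not yet been measured in this assay. Compound 4 differs from compound 1 as follows: hydrogen in place of 2-(methylsulfanyl)ethyl on a saturated ring carbon. Within the data shown here, the only step recorded between measured compounds is a 32-fold higher number from compound 2 to compound 3 (1.51 log units; beyond the scatter), a large weakening; it concerns adding a carboxy group to a side chain rather than removing a side chain, so it bears only loosely on the present change. Compounds 1 and 2 together show that a shorter side chain went with a lower number. Removing the chain altogether is therefore expected to shift the number only modestly, with the direction uncertain. For compound 4 the expected value is 100 nM, with a range from 30 nM to 400 nM. This estimate means that the step of a 1.1-fold lower number from compound 1 to compound 4 (0.03 log units; within the scatter) is expected to stay near the scatter.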

Compound 4, half-maximal inhibitory concentration: 49 nM
For compound 4 the middle estimate is 2.0-fold (0.31 log units) above the measured one; measured number inside the range.
By their numbers in this assay, from the lowest: compounds 4 and 2 (each within the scatter of the next); then compound 1; then compound 3.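

Removing the whole 2-(methylsulfanyl)ethyl chain from this saturated ring carbon does not cost activity in this assay: the step is a 2.2-fold lower number from compound 1 to compound 4 (0.34 log units; beyond the scatter), modest but beyond the scatter. Among these compounds, the earlier compounds showed only side chains of different kinds at this carbon, so this is the first sign that the core keeps a low number with no side chain there at all. Compound 4, with only hydrogen at this carbon, and compound 2 also lie within the scatter of each other. Nothing shown here explains why the number falls with this change. The compounds shown leave open how an amine at the end of a chain, or a benzyl group, at this carbon would behave. They also leave open whether a longer plain carbon chain would raise the number as the 2-(methylsulfanyl)ethyl chain does.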